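One More Bromo Gives Way to Hydrogen

The source may report more compounds than this note shows. Statements on the series, on what has been measured and on what is new or still open speak of the compounds shown alone.

Measured so far:
compound 1 `CCOc1ccc(C(=O)NNc2c(Br)cc(Br)cc2Br)cc1` gives 54800 nM
compound 2 `CCOc1ccc(C(=O)NNc2ccc(Br)cc2Br)cc1` gives > 100000 nM (a limit, not a number)

In a toxicity assay on MDCK cells (Canis lupus familiaris) for cytotoxicity, read by CCK-8 assay, with a stated time of 48 h (on this read-out higher numbers stand for lower toxicity in this test and lower numbers for higher toxicity in this test), compound 2 stands at > 100000 nM and this is a limit of the assay, not a number. Compound 3 `CCOc1ccc(C(=O)NNc2ccc(Br)cc2)cc1` comes from compound 2 through one small change hydrogen in place of bromo on an aromatic carbon that puts hydrogen in place of bromo on an aromatic carbon. For the measured compounds named here, one measured step bears on this, because the same kind of swap gave an at least 1.8-fold higher number from compound 1 to compound 2 (0.26 log units; that floor lies within the scatter) and so offers only weak guidance. A drift toward higher numbers is therefore expected, but nothing beyond the scatter. The expected step is a step that the limit leaves unreadable from compound 2 to compound 3 and remains a small one. Compound 3 is estimated at 130000 nM with an expected range from 60000 nM to 300000 nM in this assay and the result may again be only a limit.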

Compound 3, half-maximal cytotoxic concentration: > 100000 nM
Compound 3 gave a limit, no number; the forecaster's own chance of this, stated with the estimate: 75%; the middle value is on the limit's open side.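

For the compounds shown here, compound 2 and compound 3 both stand at a limit, not a number, so no step between them can be read: the limit of > 100000 nM in this assay, at which 2 of the 3 values shown sit. Left open is how far past that limit each compound lies, and whether this swap of bromo for hydrogen changes the number at all.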